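Ethyl to 2-fluorocyclopropyl on the shared amide carbonyl

This account rests on a few compounds, and the source may have more. Where it says the series, first, only, none or still open, it means among the compounds named here.

Compound 1 `CCC(=O)N1CC2CC(C1)N2` gives 98% in an assay on SH-EP1 cells for agonist activity at Neuronal acetylcholine receptor; alpha4/beta2 (Homo sapiens), read by FLIPR and calcium flux (on this read-out lower numbers stand for smaller maximal responses and higher numbers for larger maximal responses), the second highest of the three numbers measured. Compound 2 `O=C(C1CCC1)N1CC2CC(C1)N2` gives 100% in this assay, and compound 3 `O=C(C1CCCC1)N1CC2CC(C1)N2` gives 48%; compound 1 stands nearest compound 2 and furthest from compound 3. Going by the values given here, the only single-point step on record is a number 2 percentage points higher from compound 1 to compound 2 (within the scatter). Compound 4 `O=C([C@H]1C[C@@H]1F)N1CC2CC(C1)N2` differs from compound 1 by 2-fluorocyclopropyl in place of ethyl on a carbonyl carbon. Since a number 2 percentage points higher from compound 1 to compound 2 (within the scatter) lies within the scatter, compound 4 is expected to show a number 6 percentage points lower from compound 1 to compound 4 (within the scatter), that is no step beyond the scatter in this assay. Compound 4 is therefore estimated at 92%, within 70% to 105%. Among the compounds with values here, compound 3 is the one low value, and no measured step connects it to the ethyl case.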

Compound 4, largest response reached (Emax), in percent of the reference or control that the assay uses: 100%
The estimate for compound 4 lay 8 percentage points below the measured number; low and high end bracket the measured number.
By their numbers in this assay, from the lowest: compound 3; then compounds 1, 2 and 4 (each within the scatter of the next).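

In this assay, the carbonyl carbon also carries a fluorine-bearing three-membered ring with two defined stereocentres without a step beyond the scatter: a number 2 percentage points higher from compound 1 to compound 4 (within the scatter), and no change at the digits printed from compound 2 to compound 4 (within the scatter). Ethyl, cyclobutyl and 2-fluorocyclopropyl therefore sit together, while compound 3 remains the only low value at 48%. Plain cyclopropyl, the other stereoisomers of 2-fluorocyclopropyl and a longer chain such as butyl remain open. No evidence in hand accounts for the value of compound 3 or for the match among the other three compounds.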